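The compounds below may be only part of what the source reports. "The series", "measured", "known", "first", "only" and "open" are said of these compounds alone.

Measured in an ADME assay on L929 cells (Mus musculus, culture collection number NCTC 929) for cytotoxicity, read by MTT assay, with a stated time of 72 h; a higher number here means a weaker inhibitor, a lower number a stronger inhibitor:
- compound 1 `CCCCCCCCCC(=O)c1c(O)cc(C)oc1=O`: 134000 nM
- compound 2 `CCCCCCCNC(=O)c1c(O)cc(C)oc1=O`: 187000 nM
- compound 3 `Cc1cc(O)c(C(=O)Nc2ccc(OCc3ccccc3)cc2)c(=O)o1`: > 200000 nM

The values of compound 1 and compound 2 lie within the scatter of each other. The entry for compound 3 is a limit, > 200000 nM, not a number.

Compound 4 `CCCCCCCC(=O)c1c(O)cc(C)oc1=O`, still unmeasured, differs from compound 1 by hydrogen in place of ethyl on a saturated chain carbon, seven bonds along the chain from a carbonyl carbon.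

Within the data shown here, no measured pair differs in one place only. Among the measured compounds shown here, compound 1 at 134000 nM and compound 2 at 187000 nM are the only numbers to go on, so no shift beyond the scatter is expected in this assay. The estimated change is a 1.2-fold higher number from compound 1 to compound 4 (0.09 log units; within the scatter). For compound 4 the estimated value is 165000 nM, with an expected range of 90000 nM to 200000 nM.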

Compound 4, half-maximal inhibitory concentration: 140000 nM
Beside the measured number, compound 4's estimate is 1.2-fold (0.07 log units) above it, and the stated range covers the measured number.
By their numbers in this assay, from the lowest: compounds 1, 4 and 2 (each within the scatter of the next). At a limit, above all of these: compound 3.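

In this assay the series now has its first pair differing in one place: hydrogen in place of ethyl on a saturated chain carbon, seven bonds along the chain from a carbonyl carbon gives a 1.0-fold higher number from compound 1 to compound 4 (0.02 log units; within the scatter). Among these compounds, this change at this place therefore leaves the number within the scatter, which the earlier compounds, with no such pair, could not show. Nothing shown bears on a cause for this step. Still open, on these data alone, is whether a longer chain, or an amine or a carboxylic acid on this chain, would move the number in this assay.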